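A few compounds are considered here, and "the series" means these few. Any claim that something is new, unique, unknown or untested is made for them only; others in the source may bear on it.

Compound 1 `CCC(CC)[C@@H]1C(=O)N[C@H](C2Cc3ccccc3C2)C(=O)N1[C@@H](C(=O)N1CCOCC1)c1ccc(C)nc1` and compound 2 `CCC(CC)[C@@H]1C(=O)N[C@H](C2Cc3ccccc3C2)C(=O)N1[C@@H](C(=O)N(C)C)c1ccc(C)nc1` share one core and differ in a single spot: dimethylamino in place of morpholin-4-yl on a carbonyl carbon. Both were tested in an ADME assay on the whole organism (plasma) for pharmacokinetics, with Rattus norvegicus as the target, at a dose of 5 mg/kg by the oral route; on this read-out higher numbers stand for higher exposure at the dose given and lower numbers for lower exposure. Compound 1 gives 1380 ng.h/mL in this assay, and compound 2 gives 1810 ng.h/mL, so the change produced a 1.3-fold higher number from compound 1 to compound 2 (0.12 log units; within the scatter).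

Compound 3 `COc1ccc([C@H](C(=O)N2CCOCC2)N2C(=O)[C@@H](C3Cc4ccccc4C3)NC(=O)[C@H]2CC(C)C)cn1` is built on a different core; the difference between the core of compound 1 and the core of compound 3 is not broken down here. In this assay compound 3 gives 2130 ng.h/mL, a number close to those of compound 1 and compound 2.

Compound 4 `COc1ccc([C@H](C(=O)N(C)C)N2C(=O)[C@@H](C3Cc4ccccc4C3)NC(=O)[C@H]2CC(C)C)cn1` has not been measured yet. It is made from compound 3 by the same change that turned compound 1 into compound 2: dimethylamino in place of morpholin-4-yl on a carbonyl carbon. The surroundings of the changed spot read the same in both pairs, so this is the same change on a different core.

Because a 1.3-fold higher number from compound 1 to compound 2 (0.12 log units; within the scatter) lay within the scatter, compound 4 is expected to show a 1.3-fold higher number from compound 3 to compound 4 (0.10 log units; within the scatter) in this assay. Compound 4 is therefore estimated to give about 2700 ng.h/mL, with a likely range from 1300 ng.h/mL to 5500 ng.h/mL.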

Compound 4, area under the concentration-time curve in the Rattus norvegicus assay: 2230 ng.h/mL
For compound 4 the middle estimate is 1.2-fold (0.08 log units) above the measured one; the range from low to high includes it.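

In the Rattus norvegicus assay compound 3 gives 2130 ng.h/mL and compound 4 gives 2230 ng.h/mL. In the Rattus norvegicus assay, putting dimethylamino in place of morpholin-4-yl on the carbonyl carbon gives a 1.0-fold higher number from compound 3 to compound 4 (0.02 log units; within the scatter), and the step on this core agrees with the one on the earlier core: the same change on two cores in the Rattus norvegicus assay, a 1.3-fold higher number (0.12 log units; within the scatter) from compound 1 to compound 2 and a 1.0-fold higher number (0.02 log units; within the scatter) from compound 3 to compound 4, 1.3-fold (0.10 log units) apart, within the scatter of two such steps. On these two cores, then, the change carries over as a step too small to separate from repeat-measurement noise. In a physicochemical assay for lipophilicity, read by HPLC (on this read-out higher numbers stand for higher lipophilicity and lower numbers for lower lipophilicity), compound 3 gives 2.7 and compound 4 gives 2.7. In the physicochemical assay the same pair shows no change at the digits printed from compound 3 to compound 4 (within the scatter). This does not show that the change has no effect at all, since a small real effect would be hidden within the scatter, and two pairs cannot establish a rule for every core in the series.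

Going by these compounds, only morpholin-4-yl and dimethylamino appear on this carbonyl carbon, so it remains open whether piperazin-1-yl, which has a second ring nitrogen, or diethylamino, with its longer chains, would give a step beyond the scatter. On these data alone, whether the agreement would hold on a third core also remains open.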